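The compounds below may be only part of what the source reports. "The series", "measured", "known", "first", "only" and "open" are said of these compounds alone.

In a functional assay on A549 cells (Homo sapiens) for inhibition, read by MTT assay, with a stated time of 72 h (on this read-out lower numbers stand for stronger inhibition and higher numbers for weaker inhibition), compound 1 `Cc1nc(-c2ccccc2F)c(C(=O)N2CCN(c3cc(Cl)cc(Cl)c3)CC2)o1` gives 204 nM, and compound 2 `Cc1nc(-c2ccc(F)cc2)c(C(=O)N2CCN(c3cc(Cl)cc(Cl)c3)CC2)o1` gives 296 nM, the upper of the two numbers seen so far, though its gap to compound 1 lies within the scatter. Among the measured compounds shown here, the only measured step, a 1.5-fold higher number from compound 1 to compound 2 (0.16 log units; within the scatter), swapped one fluorophenyl for another. Compound 3 `Cc1nc(-c2cccc(F)c2)c(C(=O)N2CCN(c3cc(Cl)cc(Cl)c3)CC2)o1` differs from compound 2 in one place: 3-fluorophenyl in place of 4-fluorophenyl on an aromatic carbon. Because a 1.5-fold higher number from compound 1 to compound 2 (0.16 log units; within the scatter) stayed within the scatter, compound 3 is estimated at 260 nM, with a range from 110 nM to 620 nM. This estimate corresponds to an expected step of a 1.1-fold lower number from compound 2 to compound 3 (0.06 log units; within the scatter), nothing beyond the scatter.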

Compound 3, half-maximal inhibitory concentration: 354 nM
For compound 3 the middle estimate is 1.4-fold (0.13 log units) below the measured one, within the range that was stated.
By their numbers in this assay, from the lowest: compounds 1, 2 and 3 (each within the scatter of the next).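

With 3-fluorophenyl added, all three fluorophenyl groups at this position now have a value in this assay. Swapping in 3-fluorophenyl for 4-fluorophenyl gives (a 1.2-fold higher number from compound 2 to compound 3 (0.08 log units; within the scatter)), and swapping it in for 2-fluorophenyl gives (a 1.7-fold higher number from compound 1 to compound 3 (0.24 log units; within the scatter)), so moving the fluorine around this phenyl ring produces no difference beyond the scatter in these compounds. No evidence at hand explains these numbers. As far as these compounds go, it remains open whether an unsubstituted phenyl, a methoxyphenyl or a pyridyl group at this position would give a step beyond the scatter.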